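A few compounds are considered here, and "the series" means these few. Any claim that something is new, unique, unknown or untested is made for them only; others in the source may bear on it.

Compound 3 `O=C(O)C[C@@H](NC(=O)[C@@H]1CCN1S(=O)(=O)c1cc(Cl)cc(Cl)c1)c1ccc(OC2CCCC2)cc1` gives 0.5 nM in an assay on RPMI-8866 cells for inhibition of integrin alpha-4/beta-1 (Homo sapiens); on this read-out higher numbers stand for weaker inhibition and lower numbers for stronger inhibition. Among the three numbers in hand compound 3 stands second highest. Nearest is compound 2 `O=C(O)C[C@@H](NC(=O)[C@@H]1CCN1S(=O)(=O)c1cc(Cl)cc(Cl)c1)c1ccc(OC2CC2)cc1`, which in this assay gives 0.31 nM; the step of a 1.6-fold higher number from compound 2 to compound 3 (0.21 log units; within the scatter) lies within the scatter, so no order between these two is claimed. Furthest is compound 1 `CC(C)[C@H](CC(=O)O)NC(=O)[C@@H]1CCCN1S(=O)(=O)c1cc(Cl)cc(Cl)c1`, which in this assay gives 362 nM; compound 1 differs from compound 3 in more than one place, so only the two values themselves are set side by side, and the gap between them is beyond the scatter.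

Compound 4 `O=C(O)C[C@@H](NC(=O)[C@@H]1CCN1S(=O)(=O)c1cc(Cl)cc(Cl)c1)c1ccc(Br)cc1` differs from compound 3 by bromo in place of cyclopentyloxy on an aromatic carbon. Among the compounds with values here, no measured step matches this change. Within the data shown here, the single step in hand, a 1.6-fold higher number from compound 2 to compound 3 (0.21 log units; within the scatter), swaps one ring on the oxygen for another and leaves the number within the scatter; it says nothing about removing the oxygen and its ring altogether. The expectation therefore rests on compound 3 and its value 0.5 nM alone, and the data give no basis for the size of the step, so a wide range is set. Compound 4 is expected to give 3 nM in this assay, between 0.7 nM and 15 nM. This amounts to an expected step of a 6.0-fold higher number from compound 3 to compound 4 (0.78 log units; beyond the scatter).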

Compound 4, half-maximal inhibitory concentration: 2.1 nM
Beside the measured number, compound 4's estimate is 1.4-fold (0.15 log units) above it; low and high end bracket the measured number.
By their numbers in this assay, from the lowest: compounds 2 and 3 (each within the scatter of the next); then compound 4; then compound 1.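

Up to now this aromatic carbon had only shown one ring on the oxygen exchanged for another, with no step beyond the scatter. Within the data shown here, removing the whole ether for bromo gives the first such step in this assay: a 4.2-fold higher number from compound 3 to compound 4 (0.62 log units; beyond the scatter), and for the cyclopropyloxy ether a 6.8-fold higher number from compound 2 to compound 4 (0.83 log units; beyond the scatter). Both steps are modest, so compound 4 keeps a low number of 2.1 nM with a single bromine atom and no ring at this place, while nothing in hand accounts for the difference.

The compounds shown leave open how a methoxy group, an amine or a carboxylic acid on this aromatic carbon would read in this assay, and so whether the oxygen or the ring goes with the lower numbers. As far as these compounds go, the two chloro groups stay the same in compound 2, compound 3 and compound 4, so their share in these numbers is also open.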